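Series notes: diaryl and aryl-cycloalkyl methyl substituents

The compounds below may be only part of what the source reports. "The series", "measured", "known", "first", "only" and "open" are said of these compounds alone.

Among the compounds with values here, compound 3 `CCCn1c(=O)c2nc(C(c3ccccc3)C3CCCC3)[nH]c2n(CCC)c1=O` gives 400 nM in an assay on cell membranes for binding affinity to adenosine receptor A1 (Cavia porcellus) (on this read-out higher numbers stand for weaker inhibition and lower numbers for stronger inhibition), the highest of the three numbers so far. Compound 1 `CCCC(CCC)c1nc2c(=O)n(CCC)c(=O)n(CCC)c2[nH]1` gives 78 nM in this assay, and compound 2 `CCCn1c(=O)c2nc(C(c3ccccc3)C3CC3)[nH]c2n(CCC)c1=O` gives 150 nM in this assay. The one single-point step among these is a 2.7-fold higher number from compound 2 to compound 3 (0.43 log units; beyond the scatter); compound 1 carries a different substituent on the shared core and no single-point step links it to compound 2 or compound 3, so only its value stands for comparison.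

Compound 4 `CCCn1c(=O)c2nc(C(c3ccccc3)c3ccccc3)[nH]c2n(CCC)c1=O` differs from compound 3 by phenyl in place of cyclopentyl on a saturated chain carbon bound to two aromatic carbons. Within the data shown here, no measured step replaces a cycloalkyl by an aromatic ring at this position, so the only guide is the modest weakening seen from compound 2 to compound 3 when the ring grew. A phenyl is of comparable size to the cyclopentyl it replaces, so compound 4 is expected to give 500 nM in this assay, within 150 nM to 1600 nM, an estimated 1.3-fold higher number from compound 3 to compound 4 (0.10 log units; within the scatter).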

Compound 4, inhibition constant: 2100 nM
The estimate for compound 4 lay 4.2-fold (0.62 log units) below the measured number; measured number above the stated range.
By their numbers in this assay, from the lowest: compounds 1 and 2 (each within the scatter of the next); then compound 3; then compound 4.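

Within the data shown here, on the saturated chain carbon bound to two aromatic carbons, the earlier compounds showed only a change from one cycloalkyl to another, whereas phenyl gives a 5.3-fold higher number from compound 3 to compound 4 (0.72 log units; beyond the scatter) and a 14-fold higher number from compound 2 to compound 4 (1.15 log units; beyond the scatter) in this assay. Phenyl has only one heavy atom more than the cyclopentyl it replaces, and among compound 2, compound 3 and compound 4 the two saturated rings give the lower numbers and the aromatic ring gives the highest, so the type of ring at this place counts in this set and not only its size. Nothing measured here accounts for the rise.

On these data alone, what a cyclohexyl at this place would give stays open, so ring size and aromatic character remain unseparated in these compounds. Among these compounds, also open is how compound 1 relates to the ring-bearing compounds, as no single-point step links them.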